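Thiophen-3-yl in Place of Furan-3-yl on a Shared Core

The source may report more compounds than this note shows. Statements on the series, on what has been measured and on what is new or still open speak of the compounds shown alone.

Of the compounds shown here, three have so far been tested in a functional assay on HCT-116 cells (Homo sapiens), read by MTT assay, with a stated time of 72 h; a lower number here means a stronger inhibitor, a higher number a weaker inhibitor.
Compound 1 `CNc1ncnc2c1c(-c1ccsc1)cn2[C@@H]1O[C@H](CO)[C@@H](O)[C@H]1O` gives > 20000 nM, a limit of the assay.
Compound 2 `Cc1ncnc2c1c(-c1cc3ccccc3o1)cn2[C@@H]1O[C@H](CO)[C@@H](O)[C@H]1O` gives > 20000 nM, a limit of the assay.
Compound 3 `Cc1ncnc2c1c(-c1ccoc1)cn2[C@@H]1O[C@H](CO)[C@@H](O)[C@H]1O` gives > 20000 nM, a limit of the assay.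

Compound 3 thus stands at the limit, as do the two other shown values, and the limit of > 20000 nM in this assay, at which 3 of the 3 values shown sit, is the only evidence available. Going by the values given here, the single measured step, a step that the two limits leave unreadable from compound 2 to compound 3, cannot be read since both of its values are limits. Compound 4 `Cc1ncnc2c1c(-c1ccsc1)cn2[C@@H]1O[C@H](CO)[C@@H](O)[C@H]1O` differs from compound 3 by thiophen-3-yl in place of furan-3-yl on an aromatic carbon. Among the compounds with values here, no measured step bears on this change. Compound 1 carries the same thiophen-3-yl group and gives > 20000 nM, a limit. Compound 4 is therefore expected to stay at or near the limit, the expected step being a step that the limit leaves unreadable from compound 3 to compound 4. The estimate for compound 4 is 30000 nM, ranging from 12000 nM to 80000 nM.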

Compound 4, half-maximal inhibitory concentration: 460 nM
For compound 4 the middle estimate is 65-fold (1.81 log units) above the measured one; the whole stated range lies above it.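

In this assay, this position on the five-membered ring responds strongly to the group it carries: thiophen-3-yl in place of furan-3-yl gives an at least 43-fold lower number from compound 3 to compound 4 (1.63 log units; beyond the scatter), and thiophen-3-yl in place of 1-benzofuran-2-yl gives an at least 43-fold lower number from compound 2 to compound 4 (1.63 log units; beyond the scatter). With thiophen-3-yl kept, methyl in place of methylamino on an aromatic carbon gives an at least 43-fold lower number from compound 1 to compound 4 (1.63 log units; beyond the scatter). Compound 1 carries thiophen-3-yl as well, yet its > 20000 nM is a limit.

The compounds shown leave open how thiophen-2-yl would read at this position, and whether ethyl or an amine could stand in place of the methyl. The full size of these steps also stays open, since each starts from a limit: the limit of > 20000 nM in this assay, at which 3 of the 4 values shown sit.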